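The source may report more compounds than this note shows. Statements on the series, on what has been measured and on what is new or still open speak of the compounds shown alone.

Working notes on the series in a functional assay on the whole organism for antagonist activity, with Mus musculus as the target; on this read-out higher numbers stand for an effect only at larger amounts of compound and lower numbers for an effect already at smaller amounts. For the measured compounds named here, compound 2 `CCCN(CCC)C1CCCC1N(C(=O)CC)c1ccc(Cl)c(Cl)c1` gives 0.1 mg/kg, the lower of the two numbers measured so far. Compound 1 `CCC(=O)N(c1ccc(Cl)c(Cl)c1)C1CCCC1N` gives 0.8 mg/kg.

The next compound is compound 3 `C=CCN(C)C1CCCC1N(C(=O)CC)c1ccc(Cl)c(Cl)c1`, which carries allyl(methyl)amino in place of dipropylamino on a saturated ring carbon. Going by the values given here, only one measured step bears on this carbon. It is an 8.0-fold lower number from compound 1 to compound 2 (0.90 log units; beyond the scatter), where dipropylamino replaces amino, and it lies beyond the scatter. Among the compounds with values here, no measured compound carries an allyl group, and no measured pair compares two substituted amino groups, so the evidence here is thin.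

The entering group, like dipropylamino, has no free hydrogen on its nitrogen, but it has fewer heavy atoms. Only a small part of the measured gain is therefore expected to be lost, with a shift toward a higher number near the edge of the scatter. The expected step is a 2.0-fold higher number from compound 2 to compound 3 (0.30 log units; within the scatter). For compound 3 the estimated value is 0.2 mg/kg, with an expected range from 0.05 mg/kg to 0.8 mg/kg.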

Compound 3, dose for half-maximal effect: 0.2 mg/kg
For compound 3 middle estimate and measured number coincide at the digits printed, and the stated range covers the measured number.
By their numbers in this assay, from the lowest: compounds 2 and 3 (each within the scatter of the next); then compound 1.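

In this assay a 2.0-fold higher number from compound 2 to compound 3 (0.30 log units; within the scatter) does not separate allyl(methyl)amino from dipropylamino at this saturated ring carbon, even though the entering group has 5 heavy atoms against 7 for the group it replaces and brings 1 double bond outside aromatic rings. The a 4.0-fold lower number from compound 1 to compound 3 (0.60 log units; beyond the scatter) gives a second substituted amino group whose number stands apart from that of the amino group of compound 1, so the lower numbers at this carbon are no longer tied to dipropylamino alone, and neither of the two substituted amino groups shown goes against this. No measurement among the data shown gives a reason for these numbers.

From the compounds shown here alone, whether the double bond of the allyl group has any bearing stays open, and methyl(propyl)amino at the same carbon would address this directly. Also open, going by these compounds, is where a group with a single substituent on the nitrogen, such as methylamino, or a smaller one such as dimethylamino, would fall relative to compound 1 and the two substituted amino compounds.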